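Removal of the triazole arm from compound 2

This account rests on a few compounds, and the source may have more. Where it says the series, first, only, none or still open, it means among the compounds named here.

Compound 2 `O=C1c2c[n+]([O-])c3ccccc3c2C(=O)c2c1c1ccccc1n2Cc1cn(C[C@@H](O)CO)nn1` stands second highest of the three numbers in a toxicity assay on HEK-293T cells (Homo sapiens) for cytotoxicity, read by MTT assay, with a stated time of 72 h (a lower number here means a stronger inhibitor, a higher number a weaker inhibitor), where compound 2 gives 2030 nM. Its nearest neighbour is compound 1 `O=C1c2c[n+]([O-])c3ccccc3c2C(=O)c2c1c1ccccc1n2Cc1cn([C@H]2C[C@H](O)[C@@H](CO)O2)nn1`, which gives 3600 nM; the step of a 1.8-fold lower number from compound 1 to compound 2 (0.25 log units; within the scatter) is within the scatter. Its furthest neighbour is compound 3 `CC1(C)O[C@@H](CO)[C@H](Cn2cc(Cn3c4c(c5ccccc53)C(=O)c3c[n+]([O-])c5ccccc5c3C4=O)nn2)O1`, which gives 120 nM; the step of a 17-fold lower number from compound 2 to compound 3 (1.23 log units; beyond the scatter) is large and beyond the scatter, as is the step of a 30-fold lower number from compound 1 to compound 3 (1.48 log units; beyond the scatter).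

Compound 4 `O=C1c2c[n+]([O-])c3ccccc3c2C(=O)c2[nH]c3ccccc3c21` differs from compound 2 by hydrogen in place of (1-(2,3-dihydroxypropyl)-1H-1,2,3-triazol-4-yl)methyl on an aromatic nitrogen. For the measured compounds named here, the measured steps all keep the triazolylmethyl arm and vary only what hangs from the triazole; none removes the arm, so no step bears directly on this change. They do show that the arm can move the number a great deal, in compound 3, or hardly at all, between compound 1 and compound 2. The direction for compound 4 is therefore open. The number for compound 4 is expected to stay near that of compound 2, with a step of a 1.2-fold higher number from compound 2 to compound 4 (0.09 log units; within the scatter), and the estimate for compound 4 in this assay is 2500 nM within a wide range of 500 nM to 12000 nM.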

Compound 4, half-maximal inhibitory concentration: 890 nM
Compound 4: the middle estimate sits 2.8-fold (0.45 log units) above what was measured, within the range that was stated.
By their numbers in this assay, from the lowest: compound 3; then compound 4; then compounds 2 and 1 (each within the scatter of the next).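

Replacing the (1-(2,3-dihydroxypropyl)-1H-1,2,3-triazol-4-yl)methyl arm with hydrogen on the aromatic nitrogen gives a 2.3-fold lower number from compound 2 to compound 4 (0.36 log units; beyond the scatter) in this assay, a modest step beyond the scatter. For the compounds shown here, this is the first reading of the bare position, and it shows that no substituent on this nitrogen is needed for a number in this range. It also gives a reference for the arms: in this assay, compound 4 ranks below compounds 2 and 1 and above compound 3, so an arm at this position can leave the number higher or lower than hydrogen does.

On these data alone, whether a methyl group, or a short chain ending in an amine or a carboxylic acid, would fall nearer compound 4 or compound 3 remains open. No measurement shown offers a reason for this step or for the order of the four compounds.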